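A few compounds are considered here, and "the series" means these few. Any claim that something is new, unique, unknown or untested is made for them only; others in the source may bear on it.

Measured so far:
Compound 1, `O=C(O)Cc1sc(C(c2ccc(F)cc2)c2ccc(F)cc2)nc1-c1ccco1`, gives 140 nM.
Compound 3, `O=C(O)Cc1sc(C(c2ccccc2)c2ccc(F)c(F)c2)nc1-c1ccc(F)cc1`, gives 64 nM.
Compound 2, `COc1ccc(OC)c(-c2nc(C(c3ccccc3)c3ccccc3)sc2CC(=O)O)c1`, gives only a limit, > 100000 nM, which is not a number.

All three share the same core, a five-membered aromatic ring carrying a carboxymethyl group. In an in vitro functional assay on HEK285-7 cells for antagonist activity at prostaglandin D2 receptor 2 (Homo sapiens), read by BRET and beta-arrestin recruitment (a higher number here means a weaker inhibitor, a lower number a stronger inhibitor), compound 1 gives 140 nM, the higher of the two numbers obtained here, while compound 3 gives 64 nM, and the gap between them lies beyond the usual scatter of repeated measurements. For compound 2 this assay reports a limit rather than a number.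

Compound 4, `Nc1cc(-c2nc(C(c3ccc(F)cc3)c3ccc(F)cc3)sc2CC(=O)O)cc(F)n1`, has not yet been measured. It differs from compound 1 in one place: 2-amino-6-fluoropyridin-4-yl in place of furan-2-yl on an aromatic carbon. For the measured compounds named here, no pair of measured compounds shows this exchange, so the expectation rests on compound 1 alone. The step of a 1.6-fold higher number from compound 1 to compound 4 (0.20 log units; within the scatter) is expected to be small, leaning toward a weaker inhibitor, and may fall within the scatter. Compound 4 is therefore estimated to give about 220 nM in this assay, with a likely range from 50 nM to 900 nM.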

Compound 4, half-maximal inhibitory concentration: 1400 nM
Estimate against measurement, compound 4: 6.4-fold (0.80 log units) below; measured number outside the range, above it.
By their numbers in this assay, from the lowest: compound 3; then compound 1; then compound 4. At a limit, above all of these: compound 2.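

At this position, on an aromatic carbon of the shared core next to the ring nitrogen, replacing furan-2-yl with 2-amino-6-fluoropyridin-4-yl is not a neutral exchange in this assay: the step is a 10-fold higher number from compound 1 to compound 4 (1.00 log units; beyond the scatter). For the compounds shown here, this is the first step between two measured compounds that differ in one place, and it shows that the read-out depends on the group held here, in this case a six-membered aromatic ring with more heavy atoms and a hydrogen-bond donor. Nothing measured here shows which feature of the new group accounts for the weaker inhibition.

The amine and the fluorine arrive together with the new ring, so this single step cannot separate their contributions. As far as these compounds go, how an unsubstituted pyridin-4-yl group, or that ring carrying only the amine or only the fluorine, would compare remains open.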